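This account rests on a few compounds, and the source may have more. Where it says the series, first, only, none or still open, it means among the compounds named here.

Working notes on the series in a functional assay on DU-145 cells (Homo sapiens) for cytotoxicity, read by MTT assay, with a stated time of 72 h; a higher number here means that more compound is needed for the effect, a lower number that less compound is needed.

Compound 3 `CCc1cccc2c(OC)c(-c3occ(C)c3COC(C)=O)ccc12` carries a methyl on the aromatic oxygen and an acetyl on the chain oxygen. In this assay compound 3 gives only a limit, > 10 ug/mL. Compound 2 `CCc1cccc2c(OC(C)=O)c(-c3occ(C)c3COC(C)=O)ccc12` differs from compound 3 only in the acetyl on the aromatic oxygen. In this assay compound 2 likewise gives only a limit, > 10 ug/mL. The step that the two limits leave unreadable from compound 2 to compound 3 is therefore not readable in size. Compound 1 `CCOc1c(-c2occ(C)c2C(=O)O)ccc2c(CC)cccc12` has the ethoxy group of the target compound but a carboxylic acid in place of the acetylated chain. In this assay compound 1 also gives only a limit, > 10 ug/mL. Across the three measured compounds nothing stands below the limit, as noted in the limit of > 10 ug/mL in this assay, at which 3 of the 3 values shown sit.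

Compound 4 `CCOc1c(-c2occ(C)c2COC(C)=O)ccc2c(CC)cccc12` is the next member to be measured. The change from compound 3 is methyl in place of hydrogen on a saturated chain carbon bound to an oxygen on an aromatic ring. Among the compounds with values here, no measured step bears on this change with a readable size; the only step that is close, a step that the two limits leave unreadable from compound 2 to compound 3, gives no number. Compound 1 already carries the ethoxy group and sits at the same limit. The expectation for compound 4 is therefore a value at or beyond the limit again, with an expected step that the limit leaves unreadable from compound 3 to compound 4 that cannot be distinguished from none. Compound 4 is estimated at 20 ug/mL, within 8 ug/mL to 60 ug/mL.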

Compound 4, concentration for half-maximal effect: > 10 ug/mL
Compound 4: only a limit was reported; the forecaster's own chance of this, stated with the estimate: 85%; the middle value lies beyond the limit too.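

In this assay compound 4 gives > 10 ug/mL, a limit of the assay and not a number, so its steps from compound 1, compound 2 and compound 3 cannot be read. The compounds shown leave open whether any of these changes alters the concentration needed, with the whole series resting on one value: the limit of > 10 ug/mL in this assay, at which 4 of the 4 values shown sit.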